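This account rests on a few compounds, and the source may have more. Where it says the series, first, only, none or still open, it means among the compounds named here.

The series shares the core of compound 1 `COc1ccc(C(=O)/C=C/c2ccc3ccccc3n2)c2c1C=CC(C)(C)O2`, which in a functional assay on HCT-116 cells (Homo sapiens) for antiproliferative activity, read by MTT assay, with a stated time of 24 h (a higher number here means a weaker inhibitor, a lower number a stronger inhibitor), gives 4530 nM. Compound 2 `COc1ccc(C(=O)/C=C/c2ccc(C(F)(F)F)cc2)c2c1C=CC(C)(C)O2` keeps that core with a different aryl end. In this assay compound 2 gives only a limit, > 10000 nM, and no number is known for it. Compound 2 therefore stands at the weak end of what has been measured, sitting at the limit of > 10000 nM in this assay, at which 1 of the 2 values shown sits; its distance from compound 1 cannot be sized. Compound 3 `COc1ccc(C(=O)/C=C/c2ccc(O)cc2)c2c1C=CC(C)(C)O2` differs from compound 2 by hydroxy in place of trifluoromethyl on an aromatic carbon. Going by the values given here, no measured step of this kind exists, so the expected size rests on the two values alone. The expected step is an at least 1.6-fold lower number from compound 2 to compound 3 (0.22 log units; that floor lies within the scatter), toward lower numbers, though its size cannot be anchored to anything measured. Compound 3 is estimated at 6000 nM in this assay, between 2000 nM and 20000 nM, with a real chance that only a limit is returned again.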

Compound 3, half-maximal inhibitory concentration: > 10000 nM
Compound 3: a limit, no number (the forecaster's own chance of this, stated with the estimate: 35%); middle value at least 1.6-fold (0.22 log units) away from the limit.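

In this assay, compound 2 and compound 3 both return only a limit, so no step can be read between them. The compounds shown leave open whether hydroxy in place of trifluoromethyl on an aromatic carbon changes antiproliferative activity at all, and in which direction.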